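From Methoxy to Methyl on the Butyl Compound

A few compounds are considered here, and "the series" means these few. Any claim that something is new, unique, unknown or untested is made for them only; others in the source may bear on it.

In a functional assay on MDA-MB-231 cells (Homo sapiens) for antiproliferative activity, with a stated time of 4 days (a higher number here means a weaker inhibitor, a lower number a stronger inhibitor), compound 1 `COc1ccc(-c2[nH]c3ccc(OC)cc3c2C=C(C#N)C#N)cc1` gives 590 nM while compound 2 `COc1ccc(-c2[nH]c3ccc(C)cc3c2C=C(C#N)C#N)cc1` gives 280 nM and compound 3 `CCCCc1ccc2[nH]c(-c3ccc(OC)cc3)c(C=C(C#N)C#N)c2c1` gives 26 nM as the lowest number of the three. Compound 4 `CCCCc1ccc2[nH]c(-c3ccc(C)cc3)c(C=C(C#N)C#N)c2c1` has not yet been measured. It keeps the butyl chain of compound 3 and changes 4-methoxyphenyl to 4-methylphenyl: methyl in place of methoxy on an aromatic carbon with methyl in place of methoxy on an aromatic carbon.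

For the measured compounds named here, the nearest precedent is the same swap made elsewhere, on the shared core rather than on this ring. There the data show a 2.1-fold lower number from compound 1 to compound 2 (0.32 log units; beyond the scatter) as a modest step. The larger steps of a 23-fold lower number from compound 1 to compound 3 (1.36 log units; beyond the scatter) and an 11-fold lower number from compound 2 to compound 3 (1.03 log units; beyond the scatter) both involve the butyl chain, so they say little about this change. Going by the values given here, no measured pair makes the swap on the 4-methoxyphenyl group itself, which leaves the precedent only a loose guide. In this assay a small move towards a lower number is therefore expected, and the estimated step is a 1.3-fold lower number from compound 3 to compound 4 (0.11 log units; within the scatter) in size. For compound 4 the estimate is 20 nM with an expected range from 7 nM to 60 nM across repeated measurements.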

Compound 4, half-maximal inhibitory concentration: 65 nM
Compound 4: the middle estimate sits 3.3-fold (0.51 log units) below what was measured; measured number outside the range, above it.
By their numbers in this assay, from the lowest: compound 3; then compound 4; then compound 2; then compound 1.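

In this assay, for the compounds shown here, the swap on the 4-methoxyphenyl group gives a 2.5-fold higher number from compound 3 to compound 4 (0.40 log units; beyond the scatter), the first reading of this change at this position, and here methoxy holds the lower number. The swap therefore has no single direction that carries from one place on these compounds to another, and its outcome depends on where it is made: the same change on two cores in this assay, a 2.1-fold lower number (0.32 log units; beyond the scatter) from compound 1 to compound 2 and a 2.5-fold higher number (0.40 log units; beyond the scatter) from compound 3 to compound 4, 5.3-fold (0.72 log units) apart, beyond the scatter of two such steps The change removes one oxygen and the one hydrogen-bond acceptor counted for methoxy, but this single pair cannot separate the loss of that oxygen from the loss of one heavy atom.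

As far as these compounds go, only methoxy and methyl appear at this position, so it remains open how a hydroxyl, an ethoxy group or a fluorine would compare there, and which of them, if any, would give a lower number than methoxy. From the compounds shown here alone, it also remains open whether the swap on this ring would run the same way with a methyl group or a longer chain such as hexyl on the core in place of the butyl chain.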